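Swapping Chloro for Fluoro on a Weak Inhibitor

A few compounds are considered here, and "the series" means these few. Any claim that something is new, unique, unknown or untested is made for them only; others in the source may bear on it.

Within the data shown here, in a functional assay on MGC-803 cells (Homo sapiens) for inhibition, read by MTT assay, with a stated time of 48 h (on this read-out higher numbers stand for weaker inhibition and lower numbers for stronger inhibition), compound 1 (`COc1ccc(CNc2cc(OC)c(OC)c(OC)c2)cc1Cl`) gives 46200 nM, the highest of the three numbers measured so far, which makes it the weakest inhibitor of the set. Compound 3 (`C/C=C/C(=O)N(Cc1cc(OC)c(OC)c(OC)c1)c1ccc(OC)c(O)c1`) gives 6150 nM, and compound 2 (`COc1ccc(CN(C(=O)C=C(C)C)c2cc(OC)c(OC)c(OC)c2)cc1O`) gives 320 nM. Both differ from compound 1 in more than one place, so neither isolates the effect of a single change. Compound 4 (`COc1ccc(CNc2cc(OC)c(OC)c(OC)c2)cc1F`) changes one place only: fluoro in place of chloro on an aromatic carbon. Among the measured compounds shown here, no measured pair shows this swap of fluoro in place of chloro, so no step beyond the usual scatter is expected in this assay. The expected result is a 1.2-fold lower number from compound 1 to compound 4 (0.06 log units; within the scatter). Compound 4 is estimated at 40000 nM, within an expected range of 15000 nM to 100000 nM.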

Compound 4, half-maximal inhibitory concentration: 39700 nM
Estimate against measurement, compound 4: 1.0-fold (0.00 log units) above, within the range that was stated.
By their numbers in this assay, from the lowest: compound 2; then compound 3; then compounds 4 and 1 (each within the scatter of the next).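

In this assay fluoro in place of chloro on this aromatic carbon gives a 1.2-fold lower number from compound 1 to compound 4 (0.07 log units; within the scatter) and so the two halogens cannot be told apart at this position. The earlier compounds shown here differ from compound 1 in more than one place, so they could not isolate this single change. Nothing available here explains why the two read alike.

Still open, from the compounds shown here alone, is whether bromo, a nitrile or an amine on the same carbon would also stay within the scatter of compound 1.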